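Notes on compound 4 against compounds 1 to 3

The source may hold more compounds than are shown below. What is called first, only, known or untested is meant among the compounds shown, and "the series" means these compounds.

Compound 1 `CC/C(=C(/c1ccc(/C=C/C(=O)O)cc1)c1cc2ccccc2[nH]1)c1ccccc1` carries an unsubstituted phenyl on the double-bonded chain carbon, and in a functional assay on MCF7 cells (Homo sapiens) for inhibition (on this read-out higher numbers stand for weaker inhibition and lower numbers for stronger inhibition), compound 1 gives 108 nM. Compound 2 `CC/C(=C(/c1ccc(/C=C/C(=O)O)cc1)c1cc2ccccc2[nH]1)c1ccccc1C(F)(F)F` gives 8 nM, and compound 3 `CC/C(=C(/c1ccc(/C=C/C(=O)O)cc1)c1cc2ccccc2[nH]1)c1ccc(OC)cc1` gives 61 nM. Compound 2 has the lowest number of the three: a 14-fold lower number from compound 1 to compound 2 (1.13 log units; beyond the scatter), and a 7.6-fold higher number from compound 2 to compound 3 (0.88 log units; beyond the scatter). The remaining step is small, a 1.8-fold lower number from compound 1 to compound 3 (0.25 log units; within the scatter).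

Compound 4 `CC/C(=C(/c1ccc(/C=C/C(=O)O)cc1)c1cc2ccccc2[nH]1)c1ccc(C(F)(F)F)cc1Cl` differs from compound 2 in one place: 2-chloro-4-(trifluoromethyl)phenyl in place of 2-(trifluoromethyl)phenyl on a double-bonded chain carbon bound to a double-bonded chain carbon and a saturated chain carbon. A trifluoromethyl is kept, but as part of a 2-chloro-4-(trifluoromethyl)phenyl rather than a 2-(trifluoromethyl)phenyl, and a chlorine enters. Going by the values given here, no measured step covers a chlorine on this ring, and the only other measured change to it, a methoxy, stayed within the scatter (a 1.8-fold lower number from compound 1 to compound 3 (0.25 log units; within the scatter)). The large gain a 14-fold lower number from compound 1 to compound 2 (1.13 log units; beyond the scatter) came with the 2-(trifluoromethyl)phenyl itself, so giving that group up is expected to return part of it, while the retained trifluoromethyl and the added chlorine argue against a full return to the number of compound 1. Compound 4 is therefore expected to give 20 nM, with a range of 6 nM to 70 nM. The expected step is a 2.5-fold higher number from compound 2 to compound 4 (0.40 log units; beyond the scatter), a modest rise in the number.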

Compound 4, half-maximal inhibitory concentration: 27 nM
Compound 4: the middle estimate sits 1.4-fold (0.13 log units) below what was measured; the measured number falls inside the stated range.
By their numbers in this assay, from the lowest: compound 2; then compound 4; then compounds 3 and 1 (each within the scatter of the next).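

Working notes on the position: in this assay the 2-chloro-4-(trifluoromethyl)phenyl is a second substituted ring on the double-bonded chain carbon that clears the scatter against the unsubstituted phenyl (a 4.0-fold lower number from compound 1 to compound 4 (0.60 log units; beyond the scatter)), so among the compounds shown a gain at this place no longer rests on the 2-(trifluoromethyl)phenyl alone. That group still keeps its lead over the new ring (a 3.4-fold higher number from compound 2 to compound 4 (0.53 log units; beyond the scatter)), while the new ring also separates from the 4-methoxyphenyl (a 2.3-fold lower number from compound 3 to compound 4 (0.35 log units; beyond the scatter)), a group whose own step from phenyl stayed within the scatter, so compound 4 takes an intermediate place among the four rings. Nothing measured in this set speaks to the reason for these steps.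

The change swaps one ring for another in a single step, so the shares of the chlorine and of the trifluoromethyl in the 2-chloro-4-(trifluoromethyl)phenyl stay unseparated, and a ring carrying only one of the two would be needed to divide them. Also open, going by these compounds, is how a nitrile or a bromine on this ring would read against the same four compounds.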